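Swapping dimethylamino for fluoro in compound 4

The compounds below may be only part of what the source reports. "The series", "measured", "known", "first", "only" and "open" are said of these compounds alone.

Measured so far in a physicochemical assay for lipophilicity, at pH 7.4; on this read-out higher numbers stand for higher lipophilicity and lower numbers for lower lipophilicity:
- compound 1 `CC(C)CN(C1CCc2ccc(F)cc21)S(=O)(=O)c1ccc2c(c1)C(=O)CC(C1CCOCC1)O2` gives 4.03
- compound 2 `CC(C)CN(c1ccccc1F)S(=O)(=O)c1ccc2c(c1)C(=O)CC(C1CCOCC1)O2` gives 3.44
- compound 3 `CC(C)CN(c1ccc(N(C)C)cc1)S(=O)(=O)c1ccc2c(c1)C(=O)CC(C1CCOCC1)O2` gives 3.6

All three share one core and differ only in a group on the sulfonamide nitrogen. Compound 3 lies within the scatter of compound 2, and clearly under compound 1. Compound 4 `CC(C)CN(c1ccc(F)cc1)S(=O)(=O)c1ccc2c(c1)C(=O)CC(C1CCOCC1)O2` has not been measured yet. It keeps the structure of compound 3 except for one change, fluoro in place of dimethylamino on an aromatic carbon, para to a large group (fluoro in place of dimethylamino on an aromatic carbon).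

Going by the values given here, no measured step makes exactly this swap. The closest is a number 0.16 log units higher from compound 2 to compound 3 (within the scatter), which exchanges a 2-fluorophenyl group for the 4-(dimethylamino)phenyl group. The other two steps, a number 0.59 log units lower from compound 1 to compound 2 (beyond the scatter) and a number 0.43 log units lower from compound 1 to compound 3 (beyond the scatter), are modest and both start from the 6-fluoro-2,3-dihydro-1H-inden-1-yl group, so they bear on this change less directly. Going by compound 2 at 3.44, the expected change is small and slightly downward, not beyond the scatter, and the estimated step is a number 0.10 log units lower from compound 3 to compound 4 (within the scatter).

For compound 4 the estimated value is 3.5, with an expected range from 3.2 to 3.8.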

Compound 4, distribution coefficient: 3.48
Compound 4: middle estimate off by 0.02 log units, on the high side, and the stated range covers the measured number.
By their numbers in this assay, from the lowest: compounds 2, 4 and 3 (each within the scatter of the next); then compound 1.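

In this assay, the direct exchange of dimethylamino for fluoro on an aromatic carbon, para to a large group, gives a number 0.12 log units lower from compound 3 to compound 4 (within the scatter), so this position now has a like-for-like comparison, and replacing a group of 3 heavy atoms with one of 1 heavy atom leaves the two numbers within the scatter of each other. The 2-fluorophenyl and 4-fluorophenyl groups also cannot be told apart on this read-out, with a number 0.04 log units higher from compound 2 to compound 4 (within the scatter), while a number 0.55 log units lower from compound 1 to compound 4 (beyond the scatter) adds a third phenyl-bearing compound that sits clearly under the compound with the 6-fluoro-2,3-dihydro-1H-inden-1-yl group, and none of the compounds shown goes against this. Nothing available explains why these numbers fall as they do.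

On these data alone, only fluoro and dimethylamino appear at this place on the phenyl group, so it remains open whether a carboxylic acid or a hexyl chain there would stay within the scatter of compound 4 or move beyond it. As far as these compounds go, it is also open whether the same exchange would give so small a step with a different group in place of the isobutyl chain.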